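Benzoyl ester analogue on the shared core, adenosine binding

The compounds below may be only part of what the source reports. "The series", "measured", "known", "first", "only" and "open" are said of these compounds alone.

Measured compounds:
compound 1, `CC(=O)O[C@H]1C(=O)C=C(C)[C@@H]2CC3=C(C)C(=O)O[C@H]3/C=C(/C)CC[C@@H](OC(=O)C(C)C)[C@]21C`, 45000 nM
compound 2, `CCC(=O)O[C@@H]1CC/C(C)=C\[C@@H]2OC(=O)C(C)=C2C[C@H]2C(C)=CC(=O)[C@H](OC(C)=O)[C@]12C`, 3100 nM

Within the data shown here, in an assay on membranes from brain for displacement of a labelled ligand from adenosine receptor A1 (Rattus norvegicus) (on this read-out lower numbers stand for stronger inhibition and higher numbers for weaker inhibition), compound 2 stands lowest of the two numbers; its only neighbour is compound 1, separated by the step of a 15-fold lower number from compound 1 to compound 2 (1.16 log units; beyond the scatter), the change there being hydrogen in place of methyl on a saturated chain carbon bound to a carbonyl carbon and a saturated chain carbon.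

Compound 3, `CC(=O)O[C@H]1C(=O)C=C(C)[C@@H]2CC3=C(C)C(=O)O[C@H]3/C=C(/C)CC[C@@H](OC(=O)c3ccccc3)[C@]21C`, differs from compound 2 by phenyl in place of ethyl on a carbonyl carbon. Among the measured compounds shown here, this touches the same carbonyl carbon as the one measured step, which was large and ran towards lower numbers when the acyl group was made smaller. Here the acyl group grows instead, and no measured step shows what a phenyl does at this place, so the direction is open and the range wide. The step expected here reads a 1.9-fold higher number from compound 2 to compound 3 (0.29 log units; within the scatter). For compound 3 the value in this assay is estimated at 6000 nM, within 1200 nM to 30000 nM.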

Compound 3, half-maximal inhibitory concentration: 500000 nM
For compound 3 the middle estimate is 83-fold (1.92 log units) below the measured one; the measured number lies above the stated range.
By their numbers in this assay, from the lowest: compound 2; then compound 1; then compound 3.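

In this assay phenyl on this carbonyl carbon gives the highest number of the series, with a 160-fold higher number from compound 2 to compound 3 (2.21 log units; beyond the scatter) for phenyl in place of ethyl and an 11-fold higher number from compound 1 to compound 3 (1.05 log units; beyond the scatter) for phenyl in place of isopropyl. The position therefore responds strongly to an aromatic ring as well as to the change between open chains, and the three groups run ethyl, isopropyl, phenyl from the lowest number to the highest, with no compound shown going against that order. No available evidence accounts for this rise.

The compounds shown leave open whether a saturated ring such as cyclohexyl on this carbonyl carbon would follow phenyl or the open chains. They also leave open whether methyl in place of ethyl, or a longer chain such as butyl, would continue the order.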